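A few compounds are considered here, and "the series" means these few. Any claim that something is new, unique, unknown or untested is made for them only; others in the source may bear on it.

Measured compounds:
- compound 1, `Cc1cc(C)c(CN2CCc3c(Cl)cc([C@@H](CO)[C@@H]4CCOC4)c(Cl)c3C2=O)c(=O)[nH]1`, 1260 nM
- compound 2, `COc1cc(C)[nH]c(=O)c1CN1CCc2c(Cl)cc(C(OC)C3(C)COC3)c(Cl)c2C1=O`, 350 nM; 0.7 nM (2 entries)
- compound 3, `COC(c1cc(Cl)c2c(c1Cl)C(=O)N(Cc1c(C)cc(C)[nH]c1=O)CC2)C1CCN(C(=O)CO)CC1`, 70 nM; 0.25 nM (2 entries)

In an assay for inhibition of histone-lysine N-methyltransferase EZH2 variant Y641N (Homo sapiens), read by scintillation counting, with a stated time of 60 min, in the presence of a further agent that is not named here (on this read-out higher numbers stand for weaker inhibition and lower numbers for stronger inhibition), compound 1 gives 1260 nM, the highest single number shown; compound 2 has two widely separated entries, (the several entries of compound 2 in this assay, 350 nM; 0.7 nM (2 entries)), as does compound 3, (the several entries of compound 3 in this assay, 70 nM; 0.25 nM (2 entries)), so no ordering against compound 1 is drawn.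

Compound 4, `Cc1cc(C)c(CN2CCc3c(Cl)cc([C@H](CO)[C@H]4CCCO4)c(Cl)c3C2=O)c(=O)[nH]1`, is the next compound. Change from compound 1: a group of 8 heavy atoms (6 carbon, 2 oxygen; one five-membered non-aromatic ring with 1 hetero atom) in place of a group of 8 heavy atoms (6 carbon, 2 oxygen; one five-membered non-aromatic ring with 1 hetero atom), on an aromatic carbon. The same atoms are joined differently, with the two defined stereocentres rearranged alongside the five-membered ring.

Going by the values given here, no step of this kind is available in the data. The step of a 1.3-fold lower number from compound 1 to compound 4 (0.10 log units; within the scatter) is expected to stay within the scatter. Compound 4 is estimated at 1000 nM, between 300 nM and 4000 nM.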

Compound 4, inhibition constant: 8 nM
Beside the measured number, compound 4's estimate is 130-fold (2.10 log units) above it; measured number below the stated range.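

Within this assay, the step at this aromatic carbon, a 160-fold lower number from compound 1 to compound 4 (2.20 log units; beyond the scatter), shows that the position responds strongly to how the same atoms are joined, even though the group entering and the group leaving match in heavy atoms, donors and acceptors. The earlier compounds shown here offered no single-place comparison of this kind. Nothing measured here gives a cause for this step.

The ring rearrangement and the stereocentres change together, so their separate contributions remain unresolved. From the compounds shown here alone, how an amine or a carboxylic acid on this aromatic carbon would read also remains open.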